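The source may hold more compounds than are shown below. What is called first, only, known or untested is meant among the compounds shown, and "the series" means these compounds.

Measured compounds:

Compound 1, `O=C(CCN(Cc1ccc(C(=O)NO)cc1)C(=O)c1ccccc1)NCc1ccccc1`: 3310 nM
Compound 2, `Cc1ccc(NC(=O)CCN(Cc2ccc(C(=O)NO)cc2)C(=O)c2ccccc2)cc1`: 620 nM
Compound 3, `CN(C)c1ccc(C(=O)N(CCC(=O)NCc2ccccc2)Cc2ccc(C(=O)NO)cc2)cc1`: 1420 nM

All three were tested in a functional assay on SK-N-AS cells (Homo sapiens) for antiproliferative activity, with a stated time of 72 h; on this read-out lower numbers stand for stronger inhibition and higher numbers for weaker inhibition. Compound 1 gives 3310 nM in this assay. Within the data shown here, the change 4-methylphenyl in place of benzyl on an amide-type nitrogen is the first of the two amide-side replacements in the set, and it produces a 5.3-fold lower number from compound 1 to compound 2 (0.73 log units; beyond the scatter). Compound 2 stands with the lowest number of the three, its steps to compound 1 and compound 3 both beyond the scatter.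

The second measured change, (dimethylamino in place of hydrogen on an aromatic carbon), is the difference between the core of compound 1 and the core of compound 3; in this assay it yields a 2.3-fold lower number from compound 1 to compound 3 (0.37 log units; beyond the scatter), a smaller step than the amide-side one.

Compound 4, `Cc1ccc(NC(=O)CCN(Cc2ccc(C(=O)NO)cc2)C(=O)c2ccc(N(C)C)cc2)cc1`, has not yet been measured in this assay. It is related to compound 3 by 4-methylphenyl in place of benzyl on an amide-type nitrogen. The place is described in the same words as for the pair compound 1 and compound 2, so the two changes are the same change, applied here on the core of compound 3 rather than the core of compound 1.

The expectation for compound 4 rests on compound 1 going to compound 2, where the same change gave a 5.3-fold lower number from compound 1 to compound 2 (0.73 log units; beyond the scatter), and on compound 3 sitting at 1420 nM. Assuming a comparable step, compound 4 is estimated at 300 nM in this assay, spanning 120 nM to 750 nM. Among the measured compounds shown here, this amounts to an expected step of a 4.7-fold lower number from compound 3 to compound 4 (0.68 log units; beyond the scatter), allowed to be somewhat smaller than the measured one since only one example of the change exists.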

Compound 4, half-maximal inhibitory concentration: 400 nM
Compound 4: middle estimate off by 1.3-fold (0.12 log units), on the low side, within the range that was stated.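

In this assay, 4-methylphenyl in place of benzyl on an amide-type nitrogen carries over to the core of compound 3, giving a 3.6-fold lower number from compound 3 to compound 4 (0.55 log units; beyond the scatter), and the step does not differ from the one on the core of compound 1: the same change on two cores in this assay, a 5.3-fold lower number (0.73 log units; beyond the scatter) from compound 1 to compound 2 and a 3.6-fold lower number (0.55 log units; beyond the scatter) from compound 3 to compound 4, 1.5-fold (0.18 log units) apart, within the scatter of two such steps. Dimethylamino in place of hydrogen on an aromatic carbon gives a 1.6-fold lower number from compound 2 to compound 4 (0.19 log units; within the scatter), so this step does not separate the two compounds, yet it also does not differ from the step measured on the core of compound 1: the same change on two cores in this assay, a 2.3-fold lower number (0.37 log units; beyond the scatter) from compound 1 to compound 3 and a 1.6-fold lower number (0.19 log units; within the scatter) from compound 2 to compound 4, 1.5-fold (0.18 log units) apart, within the scatter of two such steps. These four compounds show that both changes carried over between these two cores in this one assay, but they do not show that either change would transfer to any other core, and they give no explanation for the size of either step.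

The compounds shown leave open whether a plain phenyl or a pyridyl on the same amide-type nitrogen would give a step of similar size to that of 4-methylphenyl. They also leave open whether a smaller amine such as methylamino, or a methoxy group, in place of dimethylamino would behave as dimethylamino does on these two cores.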